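Working notes on compound 4 from compounds 1 to 3

This account rests on a few compounds, and the source may have more. Where it says the series, first, only, none or still open, it means among the compounds named here.

Measured so far:
compound 1, `C=CCn1c(=O)n(C2C=CC(CO)O2)c2nc(N)nc(O)c21`, 84%
compound 2, `CN(C)CCCn1c(=O)n(C2OC(CO)[C@@H](O)[C@H]2O)c2nc(N)nc(O)c21`, 63%
compound 3, `CCCn1c(=O)n(C2C=CC(CO)O2)c2nc(N)nc(O)c21`, 84%

In a functional assay on the whole organism with Mus musculus as the target (on this read-out lower numbers stand for smaller maximal responses and higher numbers for larger maximal responses), compound 1 gives 84%, level with compound 3 and together the highest of the three numbers; compound 2 lies furthest from it, its number being lower beyond the scatter. For the measured compounds named here, the only step between two measured compounds that differ in one place, no change at the digits printed from compound 1 to compound 3 (within the scatter), shows no change within the scatter.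

Compound 4, `C=CCn1c(=O)n(CCCC)c2nc(N)nc(O)c21`, is not yet measured. It differs from compound 1 by a group of 4 heavy atoms (4 carbon; no ring) in place of a group of 7 heavy atoms (5 carbon, 2 oxygen; one five-membered non-aromatic ring with 1 hetero atom), on an aromatic nitrogen. Going by the values given here, no measured step bears directly on this change: the step from compound 1 to compound 3 alters only the chain on the other aromatic nitrogen and leaves the read-out where it was, so it says nothing about removing the five-membered ring. Compound 2 differs from compound 1 at both nitrogens at once, so its lower value cannot be assigned to either change alone. The expectation for compound 4 therefore rests on little; removing a ring with one hydrogen-bond donor and two acceptors is a larger change than any measured one, and a moderate fall is expected as a number 16 percentage points lower from compound 1 to compound 4 (beyond the scatter), with wide uncertainty. Compound 4 is estimated at 68%, from 40% to 92%.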

Compound 4, largest response reached (reported as maximal response), in percent of the reference or control that the assay uses: 36%
Compound 4: middle estimate off by 32 percentage points, on the high side, and the stated range ends above it.
By their numbers in this assay, from the lowest: compound 4; then compound 2; then compounds 1 and 3 (each within the scatter of the next).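

In this assay, for the compounds shown here, butyl in place of the group carrying the five-membered non-aromatic ring gives a number 48 percentage points lower from compound 1 to compound 4 (beyond the scatter) at this aromatic nitrogen, the first measured change confined to this position. Going by these compounds alone, the only earlier step that could be read, no change at the digits printed from compound 1 to compound 3 (within the scatter) in this assay, lay at the nitrogen bearing the allyl group, so the read-out is now seen to respond to a change at this second position, and strongly so for this pair of groups. Nothing at hand gives a measured reason for the fall, which stands as an observation without explanation.

The compounds shown leave open which part of the departing group matters, since the ring, the double bond, the hydrogen-bond donor and the hydrogen-bond acceptors all leave in one step. On these data alone, a hydroxybutyl chain, an aminobutyl chain or a longer alkyl chain at this nitrogen would begin to separate these features, and it also remains open whether propyl and allyl stay level at the other nitrogen when butyl sits here.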